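The compounds below may be only part of what the source reports. "The series", "measured", "known", "first", "only" and "open" are said of these compounds alone.

Series notes. The shared core is carried by compound 1 `O=C(Nc1cccc(-c2oc3cc(-c4ccc(F)cc4)ccc3c(=O)c2O)c1)c1ccccc1F`, compound 2 `O=C(Nc1cccc(-c2oc3cc(-c4ccc(F)cc4)ccc3c(=O)c2O)c1)c1ccc(C(F)(F)F)cc1` and compound 3 `O=C(Nc1cccc(-c2oc3cc(-c4ccc(F)cc4)ccc3c(=O)c2O)c1)c1cc(F)cc(F)c1`, which differ only in the aryl group on the amide carbonyl. In a functional assay on MCF7 cells (Homo sapiens) for antiproliferative activity, read by CCK-8 assay, with a stated time of 72 h (on this read-out lower numbers stand for stronger inhibition and higher numbers for weaker inhibition), compound 1 gives 7570 nM, compound 2 gives 32600 nM and compound 3 gives 2490 nM. Compound 2 therefore stands highest of the three: a 4.3-fold higher number from compound 1 to compound 2 (0.63 log units; beyond the scatter), and a 13-fold lower number from compound 2 to compound 3 (1.12 log units; beyond the scatter). Compound 4 `N#Cc1ccc(C(=O)Nc2cccc(-c3oc4cc(-c5ccc(F)cc5)ccc4c(=O)c3O)c2)cc1` follows from compound 2 by cyano in place of trifluoromethyl on an aromatic carbon. Among the compounds with values here, no measured step exchanges these two groups directly; the only steps bearing on this site are the aryl exchanges above, both of which leave compound 2 as the weakest member. A modest move toward the other amides is expected, so compound 4 is estimated at 12000 nM (range 4000 nM to 35000 nM), meaning an expected 2.7-fold lower number from compound 2 to compound 4 (0.43 log units; beyond the scatter).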

Compound 4, half-maximal inhibitory concentration: 2660 nM
For compound 4 the middle estimate is 4.5-fold (0.65 log units) above the measured one; the measured number lies below the stated range.
By their numbers in this assay, from the lowest: compounds 3 and 4 (each within the scatter of the next); then compound 1; then compound 2.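

In this assay, cyano in place of trifluoromethyl, para to a large group, brings a large drop in the number (a 12-fold lower number from compound 2 to compound 4 (1.09 log units; beyond the scatter)). Compound 4 reads level with the 3,5-difluorophenyl amide (a 1.1-fold higher number from compound 3 to compound 4 (0.03 log units; within the scatter)) and clearly lower than the 2-fluorophenyl amide (a 2.8-fold lower number from compound 1 to compound 4 (0.45 log units; beyond the scatter)), so a substituent at this place is not poor as such, and the high number of compound 2 goes with trifluoromethyl there. No measured property is at hand that bears on this step.

Going by these compounds, an amine or a carboxylic acid in place of cyano remains open. So does whether the level shared by compound 3 and compound 4 is a floor for this aryl group.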